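Replacing 2-methoxyphenyl with 4-fluorophenyl: a small step expected

The source may hold more compounds than are shown below. What is called first, only, known or untested is meant among the compounds shown, and "the series" means these compounds.

In a functional assay on LNCaP cells (Homo sapiens) for cytotoxicity, read by MTT assay, with a stated time of 24 h (a higher number here means that more compound is needed for the effect, a lower number that less compound is needed), compound 1 (`O=[N+]([O-])c1ccc(N2CCN(CCN3CCN(c4ccc([N+](=O)[O-])cc4)CC3)CC2)cc1`) gives 25200 nM while compound 2 (`COc1ccccc1N1CCN(CCN2CCN(c3ccc([N+](=O)[O-])cc3)CC2)CC1`) gives 46500 nM as its reading. Among the measured compounds shown here, these are the only two numbers so far, and repeated measurements of this kind vary by about as much as they differ, so neither compound can be ranked against the other.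

Compound 3 (`O=[N+]([O-])c1ccc(N2CCN(CCN3CCN(c4ccc(F)cc4)CC3)CC2)cc1`) has not yet been measured. It carries 4-fluorophenyl in place of the 2-methoxyphenyl of compound 2 on an amine nitrogen in a ring (4-fluorophenyl in place of 2-methoxyphenyl on an amine nitrogen in a ring) and keeps the rest of the structure.

For the measured compounds named here, one measured step touches this place: a 1.8-fold higher number from compound 1 to compound 2 (0.27 log units; within the scatter) when 2-methoxyphenyl took the place of 4-nitrophenyl. Going by the values given here, a single step is thin evidence, and no measured compound yet shows what 4-fluorophenyl does. With only a 1.8-fold higher number from compound 1 to compound 2 (0.27 log units; within the scatter) to go on, no change beyond the scatter is expected in this assay in either direction.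

The step expected here is a 1.3-fold lower number from compound 2 to compound 3 (0.12 log units; within the scatter) and no larger one is foreseen. Compound 3 is estimated at 35000 nM with an expected range of 15000 nM to 80000 nM for now.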

Compound 3, half-maximal effective concentration: 77900 nM
Compound 3: middle estimate off by 2.2-fold (0.35 log units), on the low side; low and high end bracket the measured number.
By their numbers in this assay, from the lowest: compounds 1, 2 and 3 (each within the scatter of the next, the first and the last beyond it).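

In this assay, 4-fluorophenyl in place of 2-methoxyphenyl on an amine nitrogen in a ring gives a 1.7-fold higher number from compound 2 to compound 3 (0.22 log units; within the scatter), so compound 2 and compound 3 cannot be told apart, even though the group that enters differs from the one that leaves. The new information comes from fluoro in place of nitro on an aromatic carbon, which gives a 3.1-fold higher number from compound 1 to compound 3 (0.49 log units; beyond the scatter): a modest step, but the only one here beyond the scatter, showing that more of compound 3 is needed for the effect than of compound 1. Nothing available explains this difference, and the numbers alone cannot supply a reason.

A single step beyond the scatter cannot show whether the nitro group itself matters or whether any replacement at this place would give a similar result. As far as these compounds go, a nitrile or a trifluoromethyl group on that aromatic carbon, or an unsubstituted phenyl ring on the amine nitrogen, could help settle this, and how such compounds would compare with compound 1 remains open.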